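The compounds below may be only part of what the source reports. "The series", "measured", "known", "first", "only" and "open" are said of these compounds alone.

Measured in an ADME assay on the whole organism (Rattus norvegicus, strain Sprague-Dawley), read by LC-MS, with stated times of 5 min and 24 h, at a dose of 5 mg/kg by the oral route; on this read-out higher numbers stand for a longer-lived compound and lower numbers for a shorter-lived compound:

- compound 1 `N#Cc1cnc(NC(=O)N2CCCc3cc(CN4CCOCC4=O)c(C=O)nc32)cc1S[C@H]1CCOC1`: 3.5 h
- compound 2 `COC[C@@H](C)Nc1cc(NC(=O)N2CCCc3cc(CN4CCCCOC4=O)c(C=O)nc32)ncc1C#N`: 2.48 h

Compound 1, at 3.5 h, stands level with compound 2, at 2.48 h, since the two numbers lie within the usual scatter of each other. Compound 3 `N#Cc1cnc(NC(=O)N2CCCc3cc(CN4CCOCC4=O)c(C=O)nc32)cc1S[C@@H]1CCOC1` has not yet been measured in this assay. Its difference from compound 1 is confined to one stereocentre: the two compounds have the same atoms and bonds and differ only in configuration as drawn: 1 of 1 stereo elements differ; a stereocentre at a saturated ring carbon is drawn S in compound 1 and R in compound 3. Within the data shown here, no pair of measured compounds differs in one place, so the data offer no measured step to go by, and nothing shows how this inversion acts on the read-out. A change beyond the scatter is therefore not expected, in either direction. The expected size of the change is a 1.1-fold lower number from compound 1 to compound 3 (0.03 log units; within the scatter), an estimate that stays within the scatter. For compound 3 the estimated value is 3.3 h, with an expected range from 1.9 h to 5.5 h.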

Compound 3, mean residence time: 3.65 h
Compound 3: middle estimate off by 1.1-fold (0.04 log units), on the low side, and the stated range covers the measured number.
By their numbers in this assay, from the lowest: compounds 2, 1 and 3 (each within the scatter of the next).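

In this assay, drawing the stereocentre at the saturated ring carbon as R rather than S gives a 1.0-fold higher number from compound 1 to compound 3 (0.02 log units; within the scatter), so the two forms stand level. Among these compounds, this is the first measured step between compounds that differ in one place, and it isolates this one stereocentre: the fact that compounds 1 and 3 differ only in the configuration as drawn At this position, the configuration as drawn therefore does not separate the two compounds on mean residence time.

The compounds shown leave open whether replacing the saturated ring at this position with another group, such as a piperidine ring or a chain bearing a carboxylic acid, would move the mean residence time beyond the scatter. They also leave open whether this stereocentre would stay equally silent if the rest of the core of compound 1 were different.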